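The source may report more compounds than this note shows. Statements on the series, on what has been measured and on what is new or still open speak of the compounds shown alone.

Measured compounds:
- Compound 1 `O=C(CCCCCCNC(=O)C(O)(O)C(F)(F)F)Nc1ncc(-c2ccc(Br)cc2)s1` gives 35000 nM in an assay on isolated protein for inhibition of protein deacetylase HDAC6 (Homo sapiens), read by chemiluminescence, with a stated time of 3 h; a lower number here means a stronger inhibitor, a higher number a weaker inhibitor.
- Compound 2 `COc1ccc2sc(NC(=O)CCCCCCNC(=O)C(O)(O)C(F)(F)F)nc2c1` gives 100000 nM in this assay.
- Compound 3 `O=C(CCCCCCNC(=O)C(O)(O)C(F)(F)F)Nc1ncc(-c2ccccc2)s1` gives 350000 nM in this assay.

All three share a long chain ending in a hydrated trifluoromethyl ketone amide, joined through an amide to a sulfur-containing aromatic core. Compound 2 stands second highest of the three numbers in this assay: compound 1 sits at a lower number, compound 3 at a higher one, both gaps beyond the scatter.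

Compound 4 `O=C(CCCCCCNC(=O)C(O)(O)C(F)(F)F)Nc1nc2ccccc2s1` is compound 2 with hydrogen in place of methoxy on an aromatic carbon. Among the compounds with values here, only one measured step is of the same kind, a substituent removed from an aromatic carbon: a 10-fold higher number from compound 1 to compound 3 (1.00 log units; beyond the scatter). That step weakened inhibition, though it concerns a bromo on a separate phenyl ring rather than a methoxy on the fused system of compound 2, so it is an imperfect guide. Taking it as the only available pointer, a modestly higher number is expected for compound 4, with wide uncertainty because compound 2 already gives 100000 nM and a further loss may push the result toward the edge of what this assay can report. Compound 4 is therefore estimated at 200000 nM, within 50000 nM to 800000 nM, an expected step of a 2.0-fold higher number from compound 2 to compound 4 (0.30 log units; within the scatter).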

Compound 4, half-maximal inhibitory concentration: 82000 nM
Beside the measured number, compound 4's estimate is 2.4-fold (0.39 log units) above it, within the range that was stated.
By their numbers in this assay, from the lowest: compound 1; then compounds 4 and 2 (each within the scatter of the next); then compound 3.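

Taking the methoxy off the six-membered aromatic ring of the fused system gives a 1.2-fold lower number from compound 2 to compound 4 (0.09 log units; within the scatter) in this assay, so compound 2 and compound 4 cannot be told apart, and at this place the methoxy makes no difference that the measurement can resolve. Within the data shown here, the earlier compounds could not show this, since their only step of this kind, a 10-fold higher number from compound 1 to compound 3 (1.00 log units; beyond the scatter), removes a bromo from a separate phenyl ring and lies beyond the scatter, so removing a substituent from an aromatic carbon does not have the same outcome in these two pairs. Nothing measured here explains why the two steps differ in size.

Among these compounds, what remains open is whether any group on this same aromatic carbon can move the number beyond the scatter, for example an amine or a carboxylic acid, or a bromo like the one that separates compound 1 from compound 3. Also open is whether the other positions of the same ring respond to a change any more than this one does, since the compounds shown carry a substituent at only this one place on that ring.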